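Removing the fluoro from compound 3: what to expect

The source may report more compounds than this note shows. Statements on the series, on what has been measured and on what is new or still open speak of the compounds shown alone.

Compound 1 `COc1ccc(N(C(=O)CN2C=CN(Cc3ccccc3)C(=O)C(Cc3n[nH]c4ccccc34)C2=O)C(C)C)cc1` gives in a functional assay on CHO cells for agonist activity at Melanocortin receptor 4 (Homo sapiens), read by a luciferase reporter, with a stated time of 4 h (a higher number here means that more compound is needed for the effect, a lower number that less compound is needed), 31600 nM; > 30000 nM (2 entries).
Compound 2 `CC(C)N(C(=O)CN1C=CN(c2ccccc2)C(=O)C(Cc2n[nH]c3ccccc23)C1=O)c1ccc(F)cc1` gives in this assay 282 nM.
Compound 3 `COc1ccc(N(C(=O)CN2C=CN(c3cccnc3)C(=O)C(Cc3n[nH]c4cc(F)ccc34)C2=O)C(C)C)cc1` gives in this assay 661 nM.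

Among the two compounds with a single number, compound 3 has the higher one, so more of it is needed than of compound 2, and that gap lies beyond the usual scatter of the assay. For compound 1 only the repeated entries described above exist, as recorded in the several entries of compound 1 in this assay, 31600 nM; > 30000 nM (2 entries), and its weak activity in this assay is clear from them.

Compound 4 `COc1ccc(N(C(=O)CN2C=CN(c3cccnc3)C(=O)C(Cc3n[nH]c4ccccc34)C2=O)C(C)C)cc1` is the not yet measured partner of compound 3. The two differ in one place only: hydrogen in place of fluoro on an aromatic carbon. Among the measured compounds shown here, no measured pair shows what such a change does, so the expectation rests on compound 3 alone. A change this small, far from the amide and the substituted aryl ring, is expected to give no step beyond the scatter, and the step from compound 3 to compound 4 is estimated at a 1.1-fold higher number from compound 3 to compound 4 (0.05 log units; within the scatter). Compound 4 is therefore expected to give about 750 nM in this assay, most likely between 250 nM and 2200 nM.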

Compound 4, half-maximal effective concentration: 2880 nM
Estimate against measurement, compound 4: 3.8-fold (0.58 log units) below, outside the stated range (above it).
By their numbers in this assay, from the lowest: compound 2; then compound 3; then compound 4.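

Putting hydrogen in place of the fluoro gives a 4.4-fold higher number from compound 3 to compound 4 (0.64 log units; beyond the scatter) in this assay, so a change of a single atom at this carbon moves the result beyond the scatter, and more of the compound is needed once the fluoro is gone. Among the compounds shown here, this is the first pair that differs in one place only, and it gives the first direct reading of any position: the aromatic carbon of the fused system, meta to a fused ring and para to a fused ring, is one where the group present affects the number, and here fluoro gives the lower number of the two. The compounds shown contain no measurement that bears on why this step occurs.

From the compounds shown here alone, only fluoro and hydrogen appear at this carbon, so it remains open whether chloro, a methyl group or an amine there would give a lower or a higher number than fluoro. Going by these compounds, it is also open whether the same exchange would give a step of similar size in compounds that carry other groups elsewhere on the shared core, as this reading rests on a single pair.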